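The source may report more compounds than this note shows. Statements on the series, on what has been measured and on what is new or still open speak of the compounds shown alone.

Working notes on the series, read in an ADME assay on MT4 cells (Homo sapiens) for cytotoxicity, read by MTT assay, with a stated time of 96 h; a higher number here means that more compound is tolerated, a lower number that less compound is tolerated. Going by the values given here, compound 1 (`COc1ccc(-c2nc3cc(/C(C)=N/NC(N)=O)ccc3[nH]2)c(OC)c1`) gives 21000 nM, the only number available so far. Compound 2 (`C/C(=N\NC(N)=O)c1ccc2c(c1)nc(-c1ccccc1)n2C1CCCCC1`) has the entry "not determined" (no result reported). Among the compounds with values here, compound 3 (`COc1ccc(-c2nc3cc(/C(C)=N/NC(N)=O)ccc3n2C2CCCCC2)cc1`) has the entry "not determined" (no result reported), so it has no numerical standing and offers no baseline for the step that follows.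

Compound 4 (`COc1ccc(-c2nc3cc(/C(C)=N/NC(N)=O)ccc3n2C2CCCCC2)c(OC)c1`) follows from compound 3 through one structural change, methoxy in place of hydrogen on an aromatic carbon, which turns 4-methoxyphenyl into 2,4-dimethoxyphenyl. Within the data shown here, no measured pair shows the effect of this change, so its size in this assay cannot be derived from the data. The working expectation is no step beyond the usual scatter, with no direction favoured. Among the measured compounds shown here, the only numerical anchor is compound 1 at 21000 nM, which also carries the 2,4-dimethoxyphenyl group but differs from compound 4 elsewhere. For compound 4 the expected value is 25000 nM, with an estimated range from 8000 nM to 80000 nM.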

Compound 4, half-maximal cytotoxic concentration: 23000 nM
The estimate for compound 4 lay 1.1-fold (0.04 log units) above the measured number; the measured number falls inside the stated range.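

In this assay, going by these compounds alone, cyclohexyl in place of hydrogen on an aromatic nitrogen gives a 1.1-fold higher number from compound 1 to compound 4 (0.04 log units; within the scatter), the first step that can be read: with 2,4-dimethoxyphenyl present in both compounds, this nitrogen carries a cyclohexyl with no step beyond the scatter. The change from 4-methoxyphenyl to 2,4-dimethoxyphenyl cannot be read, since compound 3 has no number, so the methoxy on this aromatic carbon remains without a measured effect. Nothing measured in the series gives a cause for this result.

Open, from the compounds shown here alone, is whether a smaller methyl, a benzyl or a chain ending in an amine on the same nitrogen would also stay within the scatter. Also open, going by these compounds, is how a fluorine or a hydroxyl would read on the aromatic carbon that carries the added methoxy.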